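This account rests on a few compounds, and the source may have more. Where it says the series, first, only, none or still open, it means among the compounds named here.

Of the compounds shown here, three have been tested so far in a functional assay on P388 cells (Mus musculus) for inhibition; on this read-out lower numbers stand for stronger inhibition and higher numbers for weaker inhibition. Compound 1 `Cc1ccc(/C=C\c2ccc3ccccc3c2)cc1` returned only a limit, > 5000 nM. Compound 2 `COc1cc(/C=C/c2cn(C(C)=O)c3ccccc23)cc(OC)c1OC` also returned only a limit, > 5000 nM. Within the data shown here, compound 3 `COc1cc(/C=C\c2cn(C(C)=O)c3ccccc23)cc(OC)c1OC` gives 2850 nM, the only actual number in this small set, which makes it the one firm reference point.

Among the measured compounds shown here, the single measured step is an at least 1.7-fold lower number from compound 2 to compound 3 (0.24 log units; that floor lies within the scatter). Its size is bounded by the limit of > 5000 nM in this assay, at which 2 of the 3 values shown sit, and its interpretation rests on (the fact that compounds 2 and 3 differ only in the configuration as drawn).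

Compound 4 `COc1cc(/C=C\c2cn(C)c3ccccc23)cc(OC)c1OC` keeps the drawn configuration of compound 3 and changes one group: methyl in place of acetyl on an aromatic nitrogen. In words, this puts methyl in place of acetyl on an aromatic nitrogen. For the measured compounds named here, no measured step involves a change at this nitrogen, so the data fix neither the size nor the direction of its effect.

With compound 3 at 2850 nM as the anchor, the expected result is no shift beyond the scatter, an estimated 1.4-fold lower number from compound 3 to compound 4 (0.15 log units; within the scatter). For compound 4, the estimated value is 2000 nM, with an expected range from 500 nM to 5000 nM.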

Compound 4, half-maximal inhibitory concentration: 3090 nM
Estimate against measurement, compound 4: 1.5-fold (0.19 log units) below, within the range that was stated.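

In this assay, the change from acetyl to methyl on the aromatic nitrogen gives a 1.1-fold higher number from compound 3 to compound 4 (0.04 log units; within the scatter). Among these compounds, this is the first step in the set with a real number at both ends, and it shows that, for this pair, the acetyl with its carbonyl is not required to keep the level of inhibition seen with compound 3. Nothing shown here explains why the two groups read alike.

What the compounds leave open is how far this tolerance extends: a plain hydrogen on this nitrogen, a longer chain such as butyl, or a carboxylic acid could each behave differently. From the compounds shown here alone, it is also open whether methyl in place of acetyl reads the same way on the E double bond of compound 2.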